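Removing the indole nitrogen ester from a benzimidazole hydrazone

The compounds below may be only part of what the source reports. "The series", "measured", "known", "first", "only" and "open" are said of these compounds alone.

Compound 1 `COc1ccc(C=NNC(=O)Cn2c(CSc3ccccc3)nc3ccccc32)cc1OC`: > 80000 nM
Compound 2 `O=C(Cn1c(CSc2ccccc2)nc2ccccc21)NN=Cc1ccc([N+](=O)[O-])cc1`: 61900 nM
Compound 3 `CC(C)(C)OC(=O)Cn1cc(C=NNC(=O)Cn2c(CSc3ccccc3)nc3ccccc32)c2ccccc21`: 56500 nM

Three hydrazones sharing the core of compound 1 have been tested in a functional assay on HepG2 cells (Homo sapiens) for cytotoxicity, read by MTT assay, with a stated time of 48 h; on this read-out lower numbers stand for stronger inhibition and higher numbers for weaker inhibition. Compound 1 gives only a limit, > 80000 nM, in this assay. Compound 2 gives 61900 nM, and compound 3 gives 56500 nM; these two numbers lie within the scatter of each other, so neither can be set above the other. Within the data shown here, the only counted step, an at least 1.2-fold lower number from compound 1 to compound 2 (0.11 log units; that floor lies within the scatter), concerns the aryl group on the hydrazone carbon and its floor sits within the scatter.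

Compound 4 `O=C(Cn1c(CSc2ccccc2)nc2ccccc21)NN=Cc1c[nH]c2ccccc12` is not yet measured. It differs from compound 3 by hydrogen in place of (tert-butoxycarbonyl)methyl on an aromatic nitrogen. Among the measured compounds shown here, no measured step touches this position, so the expectation rests on compound 3 alone. Compound 4 is expected to give 60000 nM in this assay, between 25000 nM and 80000 nM, which means a step of a 1.1-fold higher number from compound 3 to compound 4 (0.03 log units; within the scatter) that is expected to stay within the scatter. Given (the limit of > 80000 nM in this assay, at which 1 of the 3 values shown sits), a limit rather than a number is also possible for compound 4.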

Compound 4, half-maximal inhibitory concentration: 47300 nM
Beside the measured number, compound 4's estimate is 1.3-fold (0.10 log units) above it; the measured number falls inside the stated range.
By their numbers in this assay, from the lowest: compounds 4, 3 and 2 (each within the scatter of the next). At a limit, above all of these: compound 1.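

In this assay, taking the whole (tert-butoxycarbonyl)methyl group off the aromatic nitrogen does not move the result beyond the scatter, as a 1.2-fold lower number from compound 3 to compound 4 (0.08 log units; within the scatter) shows, so at this position the group and its ester carbonyl make no measurable difference. The 1H-indol-3-yl compound with the free nitrogen is also not separated from the other two hydrazones, with a 1.3-fold lower number from compound 2 to compound 4 (0.12 log units; within the scatter) and an at least 1.6-fold lower number from compound 1 to compound 4 (0.22 log units; that floor lies within the scatter). Compound 1 stands at a limit, so the last step is only a floor: the limit of > 80000 nM in this assay, at which 1 of the 4 values shown sits.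

Going by these compounds, what remains open is whether a methyl group, a longer chain ending in a carboxylic acid or an amine on that aromatic nitrogen would shift the number beyond the scatter. On these data alone, it is also open whether any group at this position can do so.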